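Hydroxy in place of hydrogen: compound 2 to compound 3

The compounds below may be only part of what the source reports. "The series", "measured", "known", "first", "only" and "open" are said of these compounds alone.

Going by the values given here, compound 2 `COC1=C(OC)[C@H](O)[C@H](C/C=C(\C)CC/C=C(\C)CCC=C(C)C)[C@@H](C)C1=O` is the only member of the series with a number in a functional assay on PC-3 cells (Homo sapiens) for inhibition, read by sulforhodamine B assay, with a stated time of 48 h (on this read-out lower numbers stand for stronger inhibition of growth and higher numbers for weaker inhibition of growth), where compound 2 gives 13500 nM. Compound 1 `COC1=C(OC)[C@H](O)[C@H](C/C=C(\C)CC/C=C(\C)C[C@@H]2C[C@@H](C)C(=O)O2)[C@@H](C)C1=O` reaches only a limit in this assay, > 30000 nM, and so yields no number (the limit of > 30000 nM in this assay, at which 1 of the 2 values shown sits). Among the compounds with values here, the one measured step, an at least 2.2-fold lower number from compound 1 to compound 2 (0.34 log units; beyond the scatter), puts a group of 5 heavy atoms in place of a group of 7 heavy atoms on a saturated chain carbon bound to a double-bonded chain carbon.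

Compound 3 `COC1=C(OC)[C@H](O)[C@H](C/C=C(\C)CC/C=C(\C)CC/C=C(\C)CO)[C@@H](C)C1=O` differs from compound 2 by hydroxy in place of hydrogen on a saturated chain carbon bound to a double-bonded chain carbon, that is, 2-methylprop-1-en-1-yl becomes 2-(hydroxymethyl)prop-1-en-1-yl. This sits at the same place as the measured step, but that step removed a ring rather than adding hydroxy, so it is only a weak guide: a change at this place can move the number, with no direction set for hydroxy. The expected step, a 1.1-fold higher number from compound 2 to compound 3 (0.05 log units; within the scatter), is therefore small and lies within the scatter. Compound 3 is estimated at 15000 nM, with a range from 5000 nM to 40000 nM.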

Compound 3, concentration for 50% growth inhibition: > 30000 nM
Compound 3 gave a limit, no number; the forecaster's own chance of this, stated with the estimate: 30%; middle value at least 2.0-fold (0.30 log units) from the limit.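

In this assay compound 3 gives > 30000 nM, which is a limit and not a number. Hydroxy in place of hydrogen on a saturated chain carbon bound to a double-bonded chain carbon now has a direction of its own, which the earlier compounds did not give: an at least 2.2-fold higher number from compound 2 to compound 3 (0.34 log units; beyond the scatter) shows that going from 2-methylprop-1-en-1-yl to 2-(hydroxymethyl)prop-1-en-1-yl weakens growth inhibition, whereas the earlier step at this place showed only that replacing the ring-bearing group could move the number. The step between compound 1 and compound 3 cannot be read, and compound 2 remains the only compound in the series with a number, so the series offers a single reference point: the limit of > 30000 nM in this assay, at which 2 of the 3 values shown sit.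

On these data alone, the full size of the loss from hydroxy stays open, with no number for compound 3. Also open, as far as these compounds go, is whether the loss is specific to hydroxy or extends to other groups at this end of the chain, such as a methoxy, an amine or a carboxylic acid, and whether a shorter chain carrying the hydroxy would read the same way.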